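Lengthening the Ether Chain Toward a Phenyl Ring

A few compounds are considered here, and "the series" means these few. Any claim that something is new, unique, unknown or untested is made for them only; others in the source may bear on it.

Three compounds share one core and differ only in the group attached through an oxygen on an aromatic ring. Compound 1 `CCOc1cc(CCc2nc(C)c(CC)s2)nc(NCc2cc(Cl)cc(NC(=O)OC(C)C)c2)c1` gives 33 nM in an assay on cells for binding affinity to Neuropeptide Y receptor type 1 (Homo sapiens); a lower number here means a stronger inhibitor, a higher number a weaker inhibitor. Compound 2 `CC/C=C\CCOc1cc(CCc2nc(C)c(CC)s2)nc(NCc2cc(Cl)cc(NC(=O)OC(C)C)c2)c1` gives 4.7 nM in this assay, the lowest of the three numbers. Compound 3 `CCc1sc(CCc2cc(OCc3ccccc3)cc(NCc3cc(Cl)cc(NC(=O)OC(C)C)c3)n2)nc1C` gives 237 nM in this assay.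

The step of a 7.0-fold lower number from compound 1 to compound 2 (0.85 log units; beyond the scatter) shows that extending the chain helped, while a 7.2-fold higher number from compound 1 to compound 3 (0.86 log units; beyond the scatter) shows that a phenyl directly on the chain carbon bound to the oxygen hurt, and a 50-fold higher number from compound 2 to compound 3 (1.70 log units; beyond the scatter) is the largest gap seen.

Compound 4 `CCc1sc(CCc2cc(OCCCc3ccccc3)cc(NCc3cc(Cl)cc(NC(=O)OC(C)C)c3)n2)nc1C` differs from compound 2 by benzyl in place of but-1-en-1-yl on a saturated chain carbon, two bonds along the chain from an oxygen on an aromatic ring. It keeps a long chain like compound 2 but ends in a ring like compound 3. The two relevant steps pull in opposite directions, so a moderate loss is expected in this assay, estimated as a 5.3-fold higher number from compound 2 to compound 4 (0.73 log units; beyond the scatter). Compound 4 is therefore expected to give about 25 nM, within the range 6 nM to 100 nM.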

Compound 4, half-maximal inhibitory concentration: 20 nM
Compound 4: middle estimate off by 1.3-fold (0.10 log units), on the high side, and the stated range covers the measured number.
By their numbers in this assay, from the lowest: compound 2; then compounds 4 and 1 (each within the scatter of the next); then compound 3.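

Moving the phenyl ring further out along the chain, as the 3-phenylpropoxy group, gives a 12-fold lower number from compound 3 to compound 4 (1.07 log units; beyond the scatter) in this assay and so shows that this position accepts a ring when it sits further from the oxygen. The ring-ended chain still falls short of the hex-3-en-1-yl chain, with a 4.3-fold higher number from compound 2 to compound 4 (0.63 log units; beyond the scatter) marking that gap. Compared with the much shorter chain, the 3-phenylpropyl group gains nothing that can be told apart from scatter, since the step is a 1.7-fold lower number from compound 1 to compound 4 (0.22 log units; within the scatter) and the two compounds stand level.

The compounds shown leave open whether the intermediate phenethoxy chain would bind as well, and whether an amine or a carboxylic acid at the chain end would be accepted. No supporting evidence is available to explain why these groups differ.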